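A few compounds are considered here, and "the series" means these few. Any claim that something is new, unique, unknown or untested is made for them only; others in the source may bear on it.

In a functional assay on the whole organism (blood, strain albino) with Mus musculus as the target, with stated times of 6 days and 4 h, at a dose of 1 mmol/kg by the oral route (a lower number here means less inhibition, a higher number more inhibition at the dose given (going by the name of the read-out)), compound 1 `Cc1cc(C)n(-c2ccc(S(=O)(=O)N3CC(=O)N(C4CCCCC4)C3=S)cc2)n1` gives 2%. Compound 2 `CCCN1C(=O)CN(S(=O)(=O)c2ccc(-n3nc(C(=O)O)cc3C)cc2)C1=S` has the lowest of the two numbers, with 1%, yet its nearest neighbour, compound 1, sits within the scatter, so the two are effectively alike. Compound 3 `Cc1cc(C(=O)O)nn1-c1ccc(S(=O)(=O)N2CC(=O)N(C3CCCCC3)C2=S)cc1` is still unmeasured; it differs from compound 2 by cyclohexyl in place of propyl on an amide-type nitrogen in a ring. Going by the values given here, no measured pair isolates this change. Compound 1 also carries cyclohexyl and gives 2%. On that ground the step is expected to be a number 1 percentage points higher from compound 2 to compound 3 (within the scatter), nothing beyond the scatter. Compound 3 is therefore expected to give 2%, somewhere from -8% to 12%.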

Compound 3, a percentage reported as inhibition, in the whole organism at one dose (the size of the read-out at that dose, not a potency): 1%
Compound 3: the middle estimate sits 1 percentage points above what was measured, within the range that was stated.
By their numbers in this assay, from the lowest: compounds 2, 3 and 1 (each within the scatter of the next).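

In this assay, the swap of cyclohexyl in place of propyl on an amide-type nitrogen in a ring gives no change at the digits printed from compound 2 to compound 3 (within the scatter), so this position now has a direct comparison, and the larger ring group leaves the read-out unmoved. Carboxy in place of methyl on an aromatic carbon likewise gives a number 1 percentage points lower from compound 1 to compound 3 (within the scatter), so neither single change separates these compounds. Nothing available explains this flat result. On these data alone, whether an amine or a longer chain on that ring nitrogen would move the number beyond the scatter remains open. So does whether any group at either place would do so.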